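This account rests on a few compounds, and the source may have more. Where it says the series, first, only, none or still open, it means among the compounds named here.

Measured so far:
- compound 1 `Cc1cccc(Nc2nc(N)nc(COc3ccc4c(C)cc(=O)oc4c3)n2)c1`: 1780 nM
- compound 2 `Cc1cc(=O)oc2cc(OCc3nc(N)nc(Nc4cccc(Cl)c4)n3)ccc12`: 1110 nM

Both compounds were tested in an assay on COS-7 cells for agonist activity at Free fatty acid receptor 1 (Homo sapiens), read by scintillation counting and inositol phosphate accumulation, with a stated time of 90 min; a lower number here means that less compound is needed, a higher number that more compound is needed for the effect. Compound 1 gives 1780 nM, the higher of the two numbers; compound 2 gives 1110 nM, and the step of a 1.6-fold lower number from compound 1 to compound 2 (0.21 log units; within the scatter) does not exceed the usual scatter.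

Compound 3 `Cc1ccc(Nc2nc(N)nc(COc3ccc4c(C)cc(=O)oc4c3)n2)cc1C` is not yet measured. It differs from compound 1 in one place: methyl in place of hydrogen on an aromatic carbon. Among the measured compounds shown here, no measured pair shows a methyl entering in place of a hydrogen, so none of the steps bears directly on this change. For the measured compounds named here, the only step available, a 1.6-fold lower number from compound 1 to compound 2 (0.21 log units; within the scatter), concerns an exchange of one group for another on the same ring and stayed within the scatter, which gives no reason to expect a large shift here either.

For compound 3 the expected step is a 1.2-fold lower number from compound 1 to compound 3 (0.07 log units; within the scatter), essentially no movement beyond the scatter. Compound 3 is therefore estimated at 1500 nM, with a range from 500 nM to 4500 nM.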

Compound 3, half-maximal effective concentration: 210 nM
Compound 3: the middle estimate sits 7.1-fold (0.85 log units) above what was measured; the whole stated range lies above it.
By their numbers in this assay, from the lowest: compound 3; then compounds 2 and 1 (each within the scatter of the next).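

In this assay, a position para to a large group and ortho to a methyl group proves sensitive: adding one methyl there, turning 3-methylphenyl into 3,4-dimethylphenyl, gives an 8.5-fold lower number from compound 1 to compound 3 (0.93 log units; beyond the scatter), whereas the earlier exchange of chloro for methyl stayed within the scatter. The 3,4-dimethylphenyl group also outdoes the 3-chlorophenyl group, with a 5.3-fold lower number from compound 2 to compound 3 (0.72 log units; beyond the scatter), so the new methyl brought a change that neither earlier compound hinted at. Nothing available here explains why a single added carbon has this effect.

The compounds shown leave open whether the new methyl would have the same effect without the methyl already on the ring, or alongside the chloro of compound 2. They also leave open how a larger or different group at this position, such as an ethyl, a methoxy or an amine, would change the number.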